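The source may hold more compounds than are shown below. What is called first, only, known or untested is meant among the compounds shown, and "the series" means these compounds.

Working notes on the series. The shared core is that of compound 1 `C=CCc1cc(C(C)=O)c(O)cc1OCC#N`, which in an assay on isolated protein for inhibition of leukotriene B4 receptor 1 (Homo sapiens), tested at 10 uM (a higher number here means more inhibition at the concentration tested (going by the name of the read-out), a lower number less inhibition), gives 20%. Compound 2 `CCc1cc(C(C)=O)c(O)cc1OCCCCCC(C)(C)c1nnnn1C` gives 99% in this assay, but it differs from the others in more than one place, so only its value is taken here. Compound 3 `C=CCc1cc(C(C)=O)c(O)cc1OCCCCC` gives 60%, the second highest of the three numbers: compound 2 stands above it beyond the scatter, compound 1 below it beyond the scatter. Within the data shown here, the one single-place step measured so far, a number 40 percentage points higher from compound 1 to compound 3 (beyond the scatter), shows the chain replacing the nitrile carried a large gain.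

Compound 4 `C=CCc1cc(C(C)=O)c(O)cc1OCCCCCC(=O)OC` is the next step from compound 3: methoxycarbonyl in place of hydrogen on a saturated chain carbon, five bonds along the chain from an oxygen on an aromatic ring. Among the measured compounds shown here, no measured step adds a group on a saturated chain carbon of this kind, so the direction rests only on the fact that the chain of compound 3 is kept and that compound 2, which carries a larger group on a longer chain, gives the highest number. A small gain beyond the scatter is therefore expected, a number 12 percentage points higher from compound 3 to compound 4 (beyond the scatter), and compound 4 is estimated at 72%, with a range from 48% to 94%.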

Compound 4, a percentage reported as inhibition, at one concentration (the size of the read-out at that concentration, not a potency): 106%
Beside the measured number, compound 4's estimate is 34 percentage points below it; the whole stated range lies below it.
By their numbers in this assay, from the lowest: compound 1; then compound 3; then compounds 2 and 4 (each within the scatter of the next).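

Methoxycarbonyl in place of hydrogen on a saturated chain carbon, five bonds along the chain from an oxygen on an aromatic ring, gives a number 46 percentage points higher from compound 3 to compound 4 (beyond the scatter) in this assay. Among these compounds, this is the first measured step at this position, and it shows that adding a group at the end of the chain, rather than exchanging one chain for another, can also carry a large gain. The read-out is a size at one concentration and not a potency, so the step does not say how far the gain extends, and nothing measured here bears on why the number rises.

Still open, as far as these compounds go, is whether a carboxylic acid or an amide at the same place keeps the gain, which would separate the methoxycarbonyl group from any other carbonyl group there. Also open, from the compounds shown here alone, is whether a shorter or a longer chain carrying the methoxycarbonyl group gives a similar number.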